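Methyl on an Aromatic Nitrogen in Two Related Pairs

This account rests on a few compounds, and the source may have more. Where it says the series, first, only, none or still open, it means among the compounds named here.

Compound 1 `c1ccc(NCc2cc3ccccc3[nH]2)cc1` and compound 2 `Cn1c(CNc2ccccc2)cc2ccccc21` share a core and differ in one place: methyl in place of hydrogen on an aromatic nitrogen. In an assay for inhibition of Amine oxidase [flavin-containing] A (Bos taurus), read by fluorescence (a higher number here means a weaker inhibitor, a lower number a stronger inhibitor), compound 1 gives 10000 nM, while compound 2 gives 10 nM, so that a 1000-fold lower number from compound 1 to compound 2 (3.00 log units; beyond the scatter). Compound 3 `CN(Cc1ccccc1)Cc1cc2ccccc2[nH]1` rests on a different core; the difference between the two cores is not broken down here. In this assay compound 3 gives 60 nM, a number that falls between those of compound 1 and compound 2. Compound 4 `CN(Cc1ccccc1)Cc1cc2ccccc2n1C` has not yet been measured. It differs from compound 3 in one place: methyl in place of hydrogen on an aromatic nitrogen. Going by the values given here, this is the same kind of change as the one from compound 1 to compound 2, though the surroundings are not identical: in the first pair the aromatic nitrogen is next to the ring atom that bears a group of 8 heavy atoms, in the second next to the ring atom that bears a large group. Among the compounds with values here, because the one measured example of this change is a 1000-fold lower number from compound 1 to compound 2 (3.00 log units; beyond the scatter), a lower number is expected for compound 4, yet compound 3 already starts far below compound 1, so a smaller step is expected: a 6.0-fold lower number from compound 3 to compound 4 (0.78 log units; beyond the scatter). Compound 4 is estimated at 10 nM, between 2 nM and 50 nM.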

Compound 4, inhibition constant: 7200 nM
The estimate for compound 4 lay 720-fold (2.86 log units) below the measured number, outside the stated range (above it).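

In this assay, methyl in place of hydrogen on an aromatic nitrogen did not carry over from one core to the other: the same change now gives a 120-fold higher number from compound 3 to compound 4 (2.08 log units; beyond the scatter). Set beside the earlier pair, the two steps run in opposite directions, and the gap is larger than the scatter allows: the same change on two cores in this assay, a 1000-fold lower number (3.00 log units; beyond the scatter) from compound 1 to compound 2 and a 120-fold higher number (2.08 log units; beyond the scatter) from compound 3 to compound 4, 120000-fold (5.08 log units) apart, beyond the scatter of two such steps. Going by these compounds alone, this shows that, in this series, the result of this change on one core cannot be relied on for the other, but with only one pair on each core it does not show what in the two cores produces the reversal, nor how the change would behave on a third core.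

The compounds shown leave open whether an ethyl group or a longer chain on the aromatic nitrogen would follow the methyl result on each core. They also leave open whether the two cores would still part ways if an acetyl group replaced the hydrogen on that nitrogen.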